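This account rests on a few compounds, and the source may have more. Where it says the series, first, only, none or still open, it means among the compounds named here.

Compound 1 `CS(=O)(=O)c1ccc(-c2nc3ccccn3c2Sc2ccccc2)cc1`: 77200 nM
Compound 2 `CCc1ccc(-c2nc3ccccn3c2Sc2ccccc2)cc1`: 61700 nM
Compound 3 `Cc1ccc(-c2nc3ccccn3c2Sc2ccccc2)cc1`: not yet measured

Within the data shown here, in a functional assay on U-87MG ATCC cells for inhibition, with U-87 MG (Homo sapiens) as the target, read by MTT assay, with a stated time of 48 h (a higher number here means a weaker inhibitor, a lower number a stronger inhibitor), compound 2 gives 61700 nM, which lies within the scatter of the only other number available. Compound 3 has hydrogen in place of methyl on a saturated chain carbon bound to an aromatic carbon, turning ethyl into methyl: hydrogen in place of methyl on a saturated chain carbon bound to an aromatic carbon. Among the measured compounds shown here, the one measured step, a 1.3-fold lower number from compound 1 to compound 2 (0.10 log units; within the scatter), put ethyl in place of methylsulfonyl and stayed within the scatter. This small edit is therefore expected to shift the number no more than the scatter. The expected step is a 1.0-fold lower number from compound 2 to compound 3 (0.01 log units; within the scatter). For compound 3 the estimate is 60000 nM, with an expected range of 30000 nM to 110000 nM.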

Compound 3, half-maximal inhibitory concentration: > 100000 nM
Compound 3 gave a limit, no number; the forecaster's own chance of this, stated with the estimate: 5%; at least 1.6-fold (0.22 log units) between middle value and limit.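

Compound 3 reaches a limit of the assay and so has no exact number: the limit of > 100000 nM in this assay, at which 1 of the 3 values shown sits. Shortening ethyl to methyl gives an at least 1.6-fold higher number from compound 2 to compound 3 (0.20 log units; that floor lies within the scatter) and putting methyl in place of methylsulfonyl gives an at least 1.2-fold higher number from compound 1 to compound 3 (0.11 log units; that floor lies within the scatter) as floors only. Unlike the earlier step, neither has a known size, so the true change may stay within the scatter or go well beyond it.

The compounds shown leave open what a longer chain such as propyl, an amine or a carboxylic acid would give in place of the ethyl group.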